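Urea in place of amide at the anilide end

The source may report more compounds than this note shows. Statements on the series, on what has been measured and on what is new or still open speak of the compounds shown alone.

Three measured compounds share one core. Compound 3 `COc1cc(Cl)cc(-c2nn(-c3cccc(NC(=O)c4cccc(C(F)(F)F)c4)c3)cc2-c2ccncc2)c1` gives the lowest reading of the three in a functional assay on K562 cells (Homo sapiens) for inhibition, read by sulforhodamine B assay, with a stated time of 48 h, tested at 10 uM (a lower number here means a stronger effect, a higher number a weaker effect of the compound at the concentration tested), at 26%. Compound 1 `COc1cc(Cl)cc(-c2nn(-c3cccc(NC(=O)c4cc(C(F)(F)F)cc(C(F)(F)F)c4)c3)cc2-c2ccncc2)c1` gives 38% in this assay, and compound 2 `COc1cc(Cl)cc(-c2nn(-c3cccc(NC(=O)c4ccc(Cl)c(Cl)c4)c3)cc2-c2ccncc2)c1` gives 46.4%. Both measured steps run toward compound 3 and lie beyond the scatter: a number 12 percentage points lower from compound 1 to compound 3 (beyond the scatter), and a number 20.4 percentage points lower from compound 2 to compound 3 (beyond the scatter).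

Compound 4 `COc1cc(Cl)cc(-c2nn(-c3cccc(NC(=O)Nc4ccc(Cl)c(Cl)c4)c3)cc2-c2ccncc2)c1` is not yet measured. Its change from compound 3 is (3,4-dichlorophenyl)amino in place of 3-(trifluoromethyl)phenyl on a carbonyl carbon. The step from compound 2 to compound 3 bears on it, since compound 2 already carries the 3,4-dichlorophenyl on the carbonyl carbon and reads higher than compound 3 by a number 20.4 percentage points lower from compound 2 to compound 3 (beyond the scatter). Among the compounds with values here, no measured pair shows the effect of the amino link that enters; that part of the change is without precedent here.

Compound 4 is therefore expected to read higher than compound 3 in this assay, by about a number 16 percentage points higher from compound 3 to compound 4 (beyond the scatter). The estimate for compound 4 is 42%, within a range of 22% to 65%.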

Compound 4, a percentage reported as activity, at one concentration (the size of the read-out at that concentration, not a potency): 10%
Estimate against measurement, compound 4: 32 percentage points above, and the stated range ends above it.
By their numbers in this assay, from the lowest: compound 4; then compound 3; then compounds 1 and 2 (each within the scatter of the next).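

Holding the 3,4-dichlorophenyl constant isolates the amino link on the carbonyl carbon, which no earlier pair could do: in this assay there is a number 36.4 percentage points lower from compound 2 to compound 4 (beyond the scatter). The earlier ordering of the amides therefore does not carry over to the urea, since the same aryl group that read higher in compound 2 than in compound 3 now gives a number 16 percentage points lower from compound 3 to compound 4 (beyond the scatter). Nothing available here accounts for the contribution of the amino link to this change.

Only the 3,4-dichlorophenyl urea is shown, so whether the amino link gives a similar step with 3-(trifluoromethyl)phenyl remains open. Within the data shown here, also open is how a carbamate oxygen or a methylene in place of the amino link would read, and these single-concentration readings give no potency for any compound.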